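Ester in place of carbamoyl in a solubility series

A few compounds are considered here, and "the series" means these few. Any claim that something is new, unique, unknown or untested is made for them only; others in the source may bear on it.

Compound 1 `COCCOC(=O)c1cc(N)c(Nc2ccc(C#N)cc2)cc1Oc1c(C)cc(/C=C/C#N)cc1C` gives 1.64 ug/mL in a physicochemical assay for solubility, read by HPLC, with a stated time of 4 h, at pH 2; on this read-out higher numbers stand for higher solubility and lower numbers for lower solubility.
Compound 2 `CCNC(=O)c1cc(N)c(Nc2ccc(C#N)cc2)cc1Oc1c(C)cc(/C=C/C#N)cc1C` gives 69.4 ug/mL in this assay.
Compound 3 `Cc1cc(/C=C/C#N)cc(C)c1Oc1cc(Nc2ccc(C#N)cc2)c(N)cc1C(N)=O` gives 2.09 ug/mL in this assay.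

Compound 3 stands second highest of the three numbers: the step of a 1.3-fold higher number from compound 1 to compound 3 (0.11 log units; within the scatter) is within the scatter, whereas the step of a 33-fold lower number from compound 2 to compound 3 (1.52 log units; beyond the scatter) is large. Compound 4 `COC(=O)c1cc(N)c(Nc2ccc(C#N)cc2)cc1Oc1c(C)cc(/C=C/C#N)cc1C` differs from compound 3 by methoxy in place of amino on a carbonyl carbon. The step that bears on this is a 1.3-fold higher number from compound 1 to compound 3 (0.11 log units; within the scatter), in which another ester stood level with the carbamoyl compound 3; the large step of a 42-fold higher number from compound 1 to compound 2 (1.63 log units; beyond the scatter) separates that ester from the ethyl amide, not from compound 3. Compound 4 is therefore expected to show no step beyond the scatter, a 1.3-fold lower number from compound 3 to compound 4 (0.12 log units; within the scatter). Compound 4 is estimated at 1.6 ug/mL, with a range from 0.4 ug/mL to 6 ug/mL.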

Compound 4, solubility: 21.8 ug/mL
Compound 4: middle estimate off by 14-fold (1.13 log units), on the low side, outside the stated range (above it).
By their numbers in this assay, from the lowest: compounds 1 and 3 (each within the scatter of the next); then compound 4; then compound 2.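

At this carbonyl carbon, the change from carbamoyl to methoxycarbonyl is not neutral (a 10-fold higher number from compound 3 to compound 4 (1.02 log units; beyond the scatter)), although the 2-methoxyethoxy ester stood level with compound 3. Esters therefore do not read as one class here: removing the methoxymethyl alone separates them (a 13-fold higher number from compound 1 to compound 4 (1.12 log units; beyond the scatter)), while the ethyl amide still keeps a modest lead (a 3.2-fold lower number from compound 2 to compound 4 (0.50 log units; beyond the scatter)). Nothing shown here explains these differences. From the compounds shown here alone, it remains open how an ethyl ester would read against compound 1 and compound 4, and where a carboxylic acid or a dimethylamide on this carbonyl carbon would fall.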